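The compounds below may be only part of what the source reports. "The series", "measured", "known", "first", "only" and "open" are said of these compounds alone.

Working notes on the series built on the core of compound 1 (`COC(=O)CCN1CCN(c2c(F)cc3c(=O)c(C(=O)O)cn(C4CC4)c3c2OC)CC1C`), as read in an ADME assay on Vero cells (Chlorocebus sabaeus) for cytotoxicity, read by MTT assay, with a stated time of 72 h; a lower number here means that less compound is tolerated, a higher number that more compound is tolerated. Compound 1 gives > 1000 ug/mL, which is a limit of the assay and not a number. Compound 2 (`CCOC(=O)CN1CCN(c2c(F)cc3c(=O)c(C(=O)O)cn(C4CC4)c3c2OC)CC1C`) gives 1000 ug/mL, the higher of the two actual numbers in the series. Compound 3 (`CO/N=C(\C)CN1CCN(c2c(F)cc3c(=O)c(C(=O)O)cn(C4CC4)c3c2OC)CC1C`) gives 49.6 ug/mL. Compound 4 (`CCO/N=C(\C)CN1CCN(c2c(F)cc3c(=O)c(C(=O)O)cn(C4CC4)c3c2OC)CC1C`) remains unmeasured. Its difference from compound 2 is a group of 6 heavy atoms (4 carbon, 1 nitrogen, 1 oxygen; no ring) in place of a group of 5 heavy atoms (3 carbon, 2 oxygen; no ring), on a saturated chain carbon bound to an amine nitrogen in a ring, so the ethoxycarbonyl leaves and a group with no common name enters on a saturated chain carbon bound to an amine nitrogen in a ring.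

Within the data shown here, two measured steps bear on this change. The first, a 20-fold lower number from compound 2 to compound 3 (1.30 log units; beyond the scatter), replaces the same ethoxycarbonyl at the same place. The second, an at least 20-fold lower number from compound 1 to compound 3 (1.30 log units; beyond the scatter), runs in the same direction. Both are large and beyond the scatter, so a large downward step of similar size is expected in this assay. The estimated change is an 18-fold lower number from compound 2 to compound 4 (1.26 log units; beyond the scatter). For compound 4 the estimate is 55 ug/mL, with an expected range of 15 ug/mL to 220 ug/mL.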

Compound 4, half-maximal cytotoxic concentration: 31.3 ug/mL
Estimate against measurement, compound 4: 1.8-fold (0.24 log units) above; low and high end bracket the measured number.
By their numbers in this assay, from the lowest: compounds 4 and 3 (each within the scatter of the next); then compound 2.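

In this assay, among these compounds, the large step is no longer tied to a single entering group: a 32-fold lower number from compound 2 to compound 4 (1.50 log units; beyond the scatter) is a second large downward step at this position, alongside the one seen for compound 3. The extension of the group itself cannot be told apart, as a 1.6-fold lower number from compound 3 to compound 4 (0.20 log units; within the scatter) shows methyl in place of hydrogen on a saturated chain carbon bound to an oxygen on an unsaturated carbon. The third step, an at least 31-fold lower number from compound 1 to compound 4 (1.50 log units; beyond the scatter), starts from a limit of the assay and not a number: the limit of > 1000 ug/mL in this assay, at which 1 of the 4 values shown sits.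

Which part of the entering group goes with the low numbers stays open. So does the reading in this assay for a longer chain on the oxygen, or for an amine or a carboxylic acid on the saturated chain carbon bound to the ring amine nitrogen.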